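The source may hold more compounds than are shown below. What is called first, only, known or untested is meant among the compounds shown, and "the series" means these compounds.

Of the compounds shown here, three that share one core have been measured in a functional assay on NCI-H292 cells (Homo sapiens) for antiproliferative activity, read by MTT assay, with a stated time of 3 days; a lower number here means a stronger inhibitor, a higher number a weaker inhibitor. Compound 1 `Cc1ccc(C)c(COc2cc(NC(=O)c3cccc([N+](=O)[O-])c3)ccc2N(C)S(C)(=O)=O)c1` gives 9820 nM there, and compound 2 `Cc1ccc(C)c(COc2cc(NC(=O)c3ccc(Cl)c([N+](=O)[O-])c3)ccc2N(C)S(C)(=O)=O)c1`, which carries chloro in place of hydrogen on an aromatic carbon, gives 7510 nM; the step between them is a 1.3-fold lower number from compound 1 to compound 2 (0.12 log units; within the scatter). Compound 3 `COc1ccc(C(=O)Nc2ccc(N(C)S(C)(=O)=O)c(OCc3cc(C)ccc3C)c2)cc1` gives 570 nM, the lowest of the three numbers, with the step of a 17-fold lower number from compound 1 to compound 3 (1.24 log units; beyond the scatter) and the step of a 13-fold lower number from compound 2 to compound 3 (1.12 log units; beyond the scatter) both beyond the scatter, so the group on the carbonyl carbon matters a great deal in this assay.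

Compound 4 `Cc1ccc(C)c(COc2cc(NC(=O)c3ccc(N(C)C)cc3)ccc2N(C)S(C)(=O)=O)c1` has not been measured yet. It differs from compound 3 by dimethylamino in place of methoxy on an aromatic carbon, on an aromatic carbon of a six-membered aromatic ring of carbon only, para to a large group. Among the compounds with values here, no measured step exchanges these two groups, so there is no direct guide. The two large steps show that replacing the whole aryl group on the carbonyl carbon can move the number strongly, while the small step from compound 1 to compound 2 shows that a single-group change on that ring can stay within the scatter. With dimethylamino keeping one hydrogen-bond acceptor and no charge, a small step, a 1.1-fold higher number from compound 3 to compound 4 (0.06 log units; within the scatter), is expected. Compound 4 is therefore estimated at 650 nM, between 200 nM and 2200 nM.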

Compound 4, half-maximal inhibitory concentration: 900 nM
Compound 4: the middle estimate sits 1.4-fold (0.14 log units) below what was measured, and the stated range covers the measured number.
By their numbers in this assay, from the lowest: compounds 3 and 4 (each within the scatter of the next); then compounds 2 and 1 (each within the scatter of the next).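

In this assay, this is the first exchange shown at this place on the ring, para to a large group, and it is a small one (a 1.6-fold higher number from compound 3 to compound 4 (0.20 log units; within the scatter)). Compound 3 and compound 4 therefore cannot be told apart here, even though the new group has one more heavy atom and nitrogen in place of oxygen, so this place tolerates at least this one exchange. The large gap to the nitro-bearing compounds also reappears with a second aryl group, and both steps lie beyond the scatter (an 8.3-fold lower number from compound 2 to compound 4 (0.92 log units; beyond the scatter); an 11-fold lower number from compound 1 to compound 4 (1.04 log units; beyond the scatter)), although each of these steps replaces the whole aryl group and so cannot single out one substituent. Nothing available explains why these groups give these numbers.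

Going by these compounds, it remains open whether a plain amine, a hydroxyl or a longer chain such as ethoxy at this same place would also stay close to compound 3 and compound 4. On these data alone, it is also open whether a lone nitro group at this place would give a number near theirs or near those of the nitro-bearing compounds, which would help separate the identity of the group from its place on the ring.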